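This account rests on a few compounds, and the source may have more. Where it says the series, first, only, none or still open, it means among the compounds named here.

Measured in a functional assay on Hep 3B2 cells (Homo sapiens) for cytotoxicity, read by MTT assay; on this read-out lower numbers stand for stronger inhibition and higher numbers for weaker inhibition:
- compound 1 `Cc1ccc2nc([C@H](CC3CCNCC3)N3C(=O)CN(c4ccc(Oc5ccccc5)cc4)C3=O)n(C)c2c1`: 16700 nM
- compound 2 `Cc1ccc2nc([C@H](CC3CCN(C(=O)C(C)C)CC3)N3C(=O)CN(c4ccc(Oc5ccccc5)cc4)C3=O)n(C)c2c1`: > 100000 nM, a limit of the assay

Compound 2 stands at the limit of > 100000 nM in this assay, at which 1 of the 2 values shown sits, so its place is fixed only by that limit and not by a number. Compound 3 `CC(C)C(=O)N1CCC(C[C@@H](c2nc3ccc(Cl)cc3n2C)N2C(=O)CN(c3ccc(Oc4ccccc4)cc3)C2=O)CC1` keeps the acylated ring nitrogen of compound 2 and differs from it by chloro in place of methyl on an aromatic carbon, which is chloro in place of methyl on an aromatic carbon. Going by the values given here, the only measured step, an at least 5.9-fold higher number from compound 1 to compound 2 (0.77 log units; beyond the scatter), lies at the amine nitrogen in a ring, so it bears on this change only indirectly. Among the compounds with values here, no measured step covers the aromatic carbon, and no change beyond the scatter is expected in this assay. The expected step is a number no higher from compound 2 to compound 3 (the limit leaves the size open). For compound 3 the estimated value is 100000 nM, with an expected range from 40000 nM to 250000 nM, and another limit is the likeliest report.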

Compound 3, half-maximal inhibitory concentration: > 100000 nM
Compound 3: only a limit was reported; the forecaster's own chance of this, stated with the estimate: 70%; the middle value lies on the limit itself.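

In this assay compound 2 and compound 3 each give a limit and not a number, so no step can be read between them: the limit of > 100000 nM in this assay, at which 2 of the 3 values shown sit.
Still open, on these data alone, is how compound 2 and compound 3 compare, and so what chloro in place of methyl does with the ring nitrogen acylated.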